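The source may hold more compounds than are shown below. What is called first, only, known or untested is meant among the compounds shown, and "the series" means these compounds.

Working notes on the series. Compound 1 `c1coc(-c2ccccc2NCC2=NCCN2)c1` gives 6.31 nM in a functional assay for activation of Alpha-1B adrenergic receptor (Homo sapiens), read by calcium flux; on this read-out lower numbers stand for an effect already at smaller amounts and higher numbers for an effect only at larger amounts of compound. Compound 2 `c1ccc(-c2ccccc2NCC2=NCCN2)nc1` gives 30.2 nM in this assay, and the step of a 4.8-fold higher number from compound 1 to compound 2 (0.68 log units; beyond the scatter) marks the exchange of the five-membered ring for the six-membered one. Compound 3 `Cc1cccnc1-c1ccccc1NCC1=NCCN1` returns in this assay only a limit, < 100000 nM, not a number. Where compound 3 stands is therefore fixed only by the limit of < 100000 nM in this assay, at which 1 of the 3 values shown sits, and the step that the limit leaves unreadable from compound 2 to compound 3 cannot be sized.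

Compound 4 `FC(F)(F)c1cccnc1-c1ccccc1NCC1=NCCN1` differs from compound 3 by trifluoromethyl in place of methyl on an aromatic carbon. For the measured compounds named here, no measured step exchanges one substituent for another at this carbon; the only step touching this position is the unreadable one from compound 2 to compound 3, so the starting point itself is uncertain. The step from compound 3 to compound 4 is expected to stay small, a step that the limit leaves unreadable from compound 3 to compound 4, with the chance that compound 4 again yields only a limit. For compound 4 the expected value in this assay is 5000 nM, with a range of 300 nM to 100000 nM.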

Compound 4, half-maximal effective concentration: < 100000 nM
Compound 4 was reported as a limit (the forecaster's own chance of this, stated with the estimate: 40%); the middle value lies beyond the limit too.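

In this assay compound 4 returns only a limit, < 100000 nM. The steps from compound 2 and compound 3 to compound 4 therefore cannot be read. The compounds shown leave open how far methyl or trifluoromethyl on this aromatic carbon actually shifts the value from that of compound 2.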